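Ether chain variation on a shared chromanone-type core

The compounds below may be only part of what the source reports. "The series", "measured", "known", "first", "only" and "open" are said of these compounds alone.

Measured so far:
Compound 1 `CC(C)CCOc1ccccc1C1CC(=O)c2ccccc2O1`: 47.6%
Compound 2 `CC(C)=CCOc1ccccc1C1CC(=O)c2ccccc2O1`: 41.8%
Compound 3 `CCCCOc1ccccc1C1CC(=O)c2ccccc2O1`: 19.3%

The three measured compounds share one core and differ only in the group on the saturated chain carbon bound to an oxygen on an aromatic ring. In a functional assay on RAW264.7 cells (Mus musculus) for inhibition, read by immunoassay, with a stated time of 12 h, tested at 30 uM (a higher number here means more inhibition at the concentration tested (going by the name of the read-out), a lower number less inhibition), compound 1 gives 47.6%, the highest of the three numbers. Its nearest neighbour is compound 2 at 41.8%; the step of a number 5.8 percentage points lower from compound 1 to compound 2 (within the scatter) lies within the scatter, so no order between compound 1 and compound 2 is claimed. Compound 3 gives 19.3%; the step of a number 28.3 percentage points lower from compound 1 to compound 3 (beyond the scatter) is beyond the scatter, as is a number 22.5 percentage points lower from compound 2 to compound 3 (beyond the scatter).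

Compound 4 `O=C1CC(c2ccccc2OCc2cccc(F)c2)Oc2ccccc21` has not yet been measured. It differs from compound 1 by 3-fluorophenyl in place of isobutyl on a saturated chain carbon bound to an oxygen on an aromatic ring. Going by the values given here, no measured step places an aromatic ring at this position, so the only guides are indirect: trimming the chain cost a number 28.3 percentage points lower from compound 1 to compound 3 (beyond the scatter), while swapping one branched group for another gave only a number 5.8 percentage points lower from compound 1 to compound 2 (within the scatter). The change to compound 4 keeps bulk at this position rather than removing it, so no step beyond the scatter is expected in either direction. For compound 4 the expected step is a number 2.6 percentage points lower from compound 1 to compound 4 (within the scatter). The estimate for compound 4 is 45%, with a range from 25% to 65%.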

Compound 4, a percentage reported as inhibition, at one concentration (the size of the read-out at that concentration, not a potency): 93.3%
For compound 4 the middle estimate is 48.3 percentage points below the measured one; the measured number lies above the stated range.
By their numbers in this assay, from the lowest: compound 3; then compounds 2 and 1 (each within the scatter of the next); then compound 4.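

Going by these compounds alone, at this position, on a saturated chain carbon bound to an oxygen on an aromatic ring, the earlier compounds compared open chains only; the aromatic ring of compound 4 shows that the position can carry a far higher read-out than those chains suggested. In this assay, 3-fluorophenyl in place of isobutyl gives (a number 45.7 percentage points higher from compound 1 to compound 4 (beyond the scatter)), and the same kind of exchange gives (a number 51.5 percentage points higher from compound 2 to compound 4 (beyond the scatter)) and (a number 74 percentage points higher from compound 3 to compound 4 (beyond the scatter)), so compound 4 stands clear of all three chain compounds, whether branched, unsaturated or straight. The shown data hold nothing that explains the jump or says what the ring contributes.

Compound 4 brings in a ring and a fluorine together, so the compounds shown cannot say how much of the change belongs to each; an unsubstituted phenyl in place of 3-fluorophenyl would separate the two, and a chlorine in place of the fluorine would test whether that atom matters at all. From the compounds shown here alone, the read-out is also a single-concentration figure, so potency remains open, as does whether a ring containing nitrogen, such as pyridyl, would hold the same level at this position.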